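The source may hold more compounds than are shown below. What is called first, only, known or untested is meant among the compounds shown, and "the series" means these compounds.

Compound 1 `O=C(c1ccc(-c2nc(-c3cccnc3)no2)s1)C(F)(F)F` gives 840 nM in an assay on isolated protein for inhibition of protein deacetylase HDAC6 (Homo sapiens) (on this read-out higher numbers stand for weaker inhibition and lower numbers for stronger inhibition), the highest number among the three measured compounds. Compound 3 `Cc1cccc(-c2noc(-c3ccc(C(=O)C(F)(F)F)s3)n2)c1` gives 680 nM, within the scatter of compound 1, while compound 2 `O=C(c1ccc(-c2nnc(-c3ccccc3)o2)s1)C(F)(F)F` gives 330 nM, a lower number that lies beyond the scatter. Among the measured compounds shown here, the only single-point step in the set, a 1.2-fold lower number from compound 1 to compound 3 (0.09 log units; within the scatter), replaces the ring on the aromatic carbon and leaves the number essentially unchanged. Compound 4 `O=C(c1ccc(-c2nc(-c3cccs3)no2)s1)C(F)(F)F` differs from compound 1 by thiophen-2-yl in place of pyridin-3-yl on an aromatic carbon. Because the same position was changed in a 1.2-fold lower number from compound 1 to compound 3 (0.09 log units; within the scatter) without a move beyond the scatter, a further ring swap there is expected to shift the number little, if at all. Compound 4 is therefore expected near 700 nM, with a range of 350 nM to 1500 nM. The expected step is a 1.2-fold lower number from compound 1 to compound 4 (0.08 log units; within the scatter).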

Compound 4, half-maximal inhibitory concentration: 670 nM
The estimate for compound 4 lay 1.0-fold (0.02 log units) above the measured number, and the stated range covers the measured number.
By their numbers in this assay, from the lowest: compound 2; then compounds 4, 3 and 1 (each within the scatter of the next).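

In this assay, the step of a 1.3-fold lower number from compound 1 to compound 4 (0.10 log units; within the scatter) shows that a five-membered aromatic ring with sulfur can replace a six-membered one with nitrogen at this carbon without a move beyond the scatter. The step of a 1.0-fold lower number from compound 3 to compound 4 (0.01 log units; within the scatter) shows that thiophen-2-yl and 3-methylphenyl are not told apart here either, so all three aromatic rings at this carbon read alike. No measured evidence bears on why these numbers stay together. Still open, from the compounds shown here alone, is whether a group without an aromatic ring at this carbon, such as an amine or a longer alkyl chain, would keep the number in the same range.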